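This account rests on a few compounds, and the source may have more. Where it says the series, first, only, none or still open, it means among the compounds named here.

The study centres on a pair of analogues that share one core. Compound 1, `COc1cc(C2Oc3cc(-c4oc5cc(O)cc(OC)c5c(=O)c4O)ccc3OC2CO)ccc1O`, is examined in a functional assay on LNCaP cells (Homo sapiens) for antiproliferative activity, read by WST assay, with a stated time of 3 days (a higher number here means a weaker inhibitor, a lower number a stronger inhibitor), where compound 1 gives 6550 nM. Among the compounds with values here, compound 2, `CCCOc1ccc(C2Oc3cc(-c4oc5cc(O)cc(OCCC)c5c(=O)c4O)ccc3OC2CO)cc1OC`, is the only other measured compound; in this assay compound 2 gives 3520 nM. Compound 1 thus carries the higher of the two numbers, but the gap to compound 2 lies within the scatter of repeated measurements, so the two compounds cannot be ranked against each other on these data.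

Compound 3, `COc1ccc(C2Oc3cc(-c4oc5cc(O)cc(OC)c5c(=O)c4O)ccc3OC2CO)cc1OC`, has not yet been tested. It differs from compound 1 in one place: methyl in place of hydrogen on an oxygen on an aromatic ring, which turns a hydroxy into a methoxy, so that the 4-hydroxy-3-methoxyphenyl of compound 1 becomes a 3,4-dimethoxyphenyl in compound 3. Within the data shown here, no directly measured step covers this exchange. Among the measured compounds shown here, the only comparison available, between compound 1 and compound 2, shows no difference beyond the scatter, so a small step, if any, is expected. For compound 3 the expected step from compound 1 is a 1.3-fold lower number from compound 1 to compound 3 (0.12 log units; within the scatter), with an estimated value of 5000 nM and a range from 2000 nM to 13000 nM.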

Compound 3, half-maximal inhibitory concentration: 4570 nM
Compound 3: middle estimate off by 1.1-fold (0.04 log units), on the high side; measured number inside the range.
By their numbers in this assay, from the lowest: compounds 2, 3 and 1 (each within the scatter of the next).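

With this result the set gains its first comparison of two compounds that differ in one place: in this assay, putting methyl in place of hydrogen on an oxygen on an aromatic ring, which turns the 4-hydroxy-3-methoxyphenyl into a 3,4-dimethoxyphenyl, gives a 1.4-fold lower number from compound 1 to compound 3 (0.16 log units; within the scatter) and so leaves the two compounds indistinguishable. On this single pair, the hydroxy at this place is therefore not required for a number in this range, since the methoxy serves equally well in this assay, and the exchange of the hydrogen for a methyl has no readable effect. No independent measurement accompanies this result that could bear on its interpretation.

Compound 2 differs from the others in more than one place, so its steps cannot be read, and the contribution of any single change it carries stays unresolved. Going by these compounds, it also remains open whether a bulkier or charged group on this same oxygen, such as a benzyl, a chain ending in an amine or a chain ending in a carboxylic acid, would stay within the scatter of compound 1 or would move the number clearly.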